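The compounds below may be only part of what the source reports. "The series", "measured", "known", "first", "only" and "open" are said of these compounds alone.

Measured compounds:
Compound 1, `CCCCN(c1nc2c(C(=O)NC)cccc2o1)[C@H](C)c1ccc(-c2ccccc2-c2nnn[nH]2)cc1`, gives 0.000975.
Compound 2, `CCCCN(c1nc2c(C(=O)NS(C)(=O)=O)cccc2o1)[C@H](C)c1ccc(-c2ccccc2-c2nnn[nH]2)cc1`, gives 0.00103.
Compound 3, `CCCCN(c1nc2c(NC(C)=O)cccc2o1)[C@H](C)c1ccc(-c2ccccc2-c2nnn[nH]2)cc1`, gives 0.00102.

In an ADME assay on the whole organism (plasma, Macaca fascicularis) for protein binding, read by LC-MS, using equilibrium dialysis and cassette dosing, with a stated time of 24 h, at a dose of 1 mg/kg by the oral route (on this read-out lower numbers stand for a smaller free fraction and higher numbers for a larger free fraction), compound 3 stands second highest of the three numbers, but all three lie within the scatter of one another: a 1.0-fold lower number from compound 2 to compound 3 (0.00 log units; within the scatter) and a 1.0-fold higher number from compound 1 to compound 3 (0.02 log units; within the scatter), so no ordering among them can be claimed. Compound 4, `CCCCN(c1nc2c(-c3ccccn3)cccc2o1)[C@H](C)c1ccc(-c2ccccc2-c2nnn[nH]2)cc1`, differs from compound 3 in one place: pyridin-2-yl in place of acetamido on an aromatic carbon.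

The measured steps offer only indirect guidance. Each of them, a 1.1-fold higher number from compound 1 to compound 2 (0.02 log units; within the scatter), a 1.0-fold higher number from compound 1 to compound 3 (0.02 log units; within the scatter) and a 1.0-fold lower number from compound 2 to compound 3 (0.00 log units; within the scatter), swaps one small group on the same aromatic carbon for another, and none moves the free fraction beyond the scatter. The step to compound 4 is different in kind: a group with one hydrogen-bond donor and one acceptor leaves, and a six-membered aromatic ring enters. Among the compounds with values here, there is no measured pair that exchanges such a group for an aromatic ring, so the three steps above cannot fix the size of this one. Given that every change on this carbon so far has left this assay unmoved, only a modest shift is expected, with a lean toward a smaller free fraction: the expected step is a 1.5-fold lower number from compound 3 to compound 4 (0.16 log units; within the scatter). Compound 4 is estimated at 0.0007, within a range from 0.0003 to 0.0016.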

Compound 4, unbound fraction: 0.00129
Compound 4: middle estimate off by 1.8-fold (0.27 log units), on the low side; the measured number falls inside the stated range.
By their numbers in this assay, from the lowest: compounds 1, 3, 2 and 4 (each within the scatter of the next).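

In this assay, pyridin-2-yl on this aromatic carbon gives a 1.3-fold higher number from compound 3 to compound 4 (0.10 log units; within the scatter), a 1.3-fold higher number from compound 2 to compound 4 (0.10 log units; within the scatter) and a 1.3-fold higher number from compound 1 to compound 4 (0.12 log units; within the scatter). The earlier compounds shown here exchanged only groups without a ring, whereas this change brings in a six-membered aromatic ring and, compared with acetamido, gives up the hydrogen-bond donor, yet the free fraction still cannot be told apart from that of the other three compounds. So across these four compounds, a ring on this carbon separates from the open-chain groups no more than those groups separate from one another, and nothing available here explains this insensitivity.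

The compounds shown leave open whether a carboxylic acid or a primary amine on this carbon would also leave the free fraction where it is, since neither group is among these four. All four also share everything outside this one carbon, so they cannot tell whether a change elsewhere, such as a longer chain in place of the butyl group, would shift the number in this assay.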